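A Methyl on the Ring Nitrogen, Tried a Second Time

This account rests on a few compounds, and the source may have more. Where it says the series, first, only, none or still open, it means among the compounds named here.

Of the compounds shown here, three sharing a core have been measured in an assay on HeLa cells for displacement of a labelled ligand from 5-hydroxytryptamine receptor 6 (Homo sapiens); a lower number here means a stronger inhibitor, a higher number a weaker inhibitor. Compound 1 `O=S(=O)(c1ccccc1F)c1cn(C2CCNC2)c2ncccc12` gives 2 nM. Compound 2 `CN1CCC(n2cc(S(=O)(=O)c3ccccc3F)c3cccnc32)C1` differs from compound 1 by methyl in place of hydrogen on an amine nitrogen in a ring; in this assay compound 2 gives 5.6 nM, which is a step of a 2.8-fold higher number from compound 1 to compound 2 (0.45 log units; beyond the scatter). Compound 3 `O=S(=O)(c1ccc(Cl)cc1)c1cn(C2CCCNC2)c2ncccc12` carries a different outer part, and how its core differs from the core of compound 1 is not broken down here. In this assay compound 3 gives 7.6 nM, a higher number than compound 1 shows, while the values of compound 2 and compound 3 lie within the scatter of each other.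

Compound 4 `CN1CCCC(n2cc(S(=O)(=O)c3ccc(Cl)cc3)c3cccnc32)C1` has not yet been measured. It differs from compound 3 by methyl in place of hydrogen on an amine nitrogen in a ring. Going by the values given here, this is the same kind of change as the one from compound 1 to compound 2, but not the same: there the methyl enters on an amine nitrogen of a five-membered non-aromatic ring with one nitrogen, here on an amine nitrogen of a six-membered non-aromatic ring with one nitrogen, in both cases two ring bonds from the ring atom that bears a large group. Among the compounds with values here, the single earlier example of this change raised the number modestly. On that basis the step from compound 3 to compound 4 is expected to be a 2.1-fold higher number from compound 3 to compound 4 (0.32 log units; beyond the scatter). Within the data shown here, the ring holding the nitrogen is not the same, and only one earlier example exists, which leaves this expectation loose. Compound 4 is therefore estimated at 16 nM in this assay, with a range from 7 nM to 38 nM.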

Compound 4, inhibition constant: 11.5 nM
Compound 4: middle estimate off by 1.4-fold (0.14 log units), on the high side; the measured number falls inside the stated range.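

In this assay, methyl in place of hydrogen on the amine nitrogen of the six-membered ring leads to a 1.5-fold higher number from compound 3 to compound 4 (0.18 log units; within the scatter), so on this core the effect of the change cannot be told apart from the ordinary spread of repeated measurements. Set beside the earlier example, the two steps point the same way and do not differ measurably in size: the same change on two cores in this assay, a 2.8-fold higher number (0.45 log units; beyond the scatter) from compound 1 to compound 2 and a 1.5-fold higher number (0.18 log units; within the scatter) from compound 3 to compound 4, 1.9-fold (0.27 log units) apart, within the scatter of two such steps. This shows that the change carried over from one core to the other without a detectable difference in its effect, but two pairs are a thin base for a rule, and they do not show that the same would hold on any further core or why the number moves at all.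

The compounds shown carry only hydrogen or methyl on this nitrogen, so it remains open how an ethyl group, a longer chain or an acetyl group would fare there. Compound 1 and compound 3 also differ in more than one place, which leaves open whether the ring size, the outer part or neither has any bearing on the size of the step.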